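Ethynyl to ethenyl linker change toward compound 3

A few compounds are considered here, and "the series" means these few. Any claim that something is new, unique, unknown or untested is made for them only; others in the source may bear on it.

Among the compounds with values here, compound 2 `Cc1ccc(-n2nccn2)c(C(=O)N2C[C@H](C#Cc3ccc(F)cn3)CC[C@H]2C)c1` gives 24 nM in a functional assay on isolated protein for antagonist activity at Orexin receptor type 2 (Homo sapiens), read by FLIPR and calcium flux (a lower number here means a stronger inhibitor, a higher number a weaker inhibitor), the lowest of the two numbers so far; compound 1 `Cc1ccc(-n2nccn2)c(C(=O)N2C[C@H](C#Cc3cnccc3O)CC[C@H]2C)c1` gives 52 nM in this assay, and the step of a 2.2-fold lower number from compound 1 to compound 2 (0.34 log units; beyond the scatter) came with 5-fluoropyridin-2-yl in place of 4-hydroxypyridin-3-yl on a triple-bonded carbon. Compound 3 `Cc1ccc(-n2nccn2)c(C(=O)N2C[C@H](/C=C\c3ccc(F)cn3)CC[C@H]2C)c1` differs from compound 2 by 2-(5-fluoropyridin-2-yl)ethenyl in place of 2-(5-fluoropyridin-2-yl)ethynyl on a saturated ring carbon and nothing else. Within the data shown here, no measured step touches the linker; the only step in this set concerns the aryl group and offers no direct guide. A modest shift in either direction, or none beyond the scatter, is expected. Compound 3 is estimated at 40 nM with a range from 12 nM to 130 nM in this assay. That estimate means a step of a 1.7-fold higher number from compound 2 to compound 3 (0.22 log units; within the scatter) in this assay.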

Compound 3, half-maximal inhibitory concentration: 417 nM
For compound 3 the middle estimate is 10-fold (1.02 log units) below the measured one; measured number outside the range, above it.
By their numbers in this assay, from the lowest: compound 2; then compound 1; then compound 3.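

In this assay, the linker on this saturated ring carbon proves decisive: with the 5-fluoropyridin-2-yl group held constant, ethenyl in place of ethynyl gives a 17-fold higher number from compound 2 to compound 3 (1.24 log units; beyond the scatter) and exceeds the aryl step seen earlier. The comparison an 8.0-fold higher number from compound 1 to compound 3 (0.90 log units; beyond the scatter) changes both linker and aryl group, and it leaves the ethenyl compound behind both ethynyl compounds. No measurement here accounts for the loss.

As far as these compounds go, whether the 4-hydroxypyridin-3-yl group on an ethenyl linker shows a similar step remains open. So does how a saturated ethyl linker would compare in this position.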